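A few compounds are considered here, and "the series" means these few. Any claim that something is new, unique, unknown or untested is made for them only; others in the source may bear on it.

Measured: compound 1 `O=C(Nc1ccc2nc(NC(=O)C3CCCCC3)sc2c1)c1ccccc1Cl`, 0.025 ug/mL; compound 2 `N#Cc1cccc(C(=O)Nc2ccc3nc(NC(=O)C4CCCCC4)sc3c2)c1`, 0.52 ug/mL.

Among the measured compounds shown here, in a functional assay on WI-38 VA13 cells (Homo sapiens) for cytotoxicity (on this read-out lower numbers stand for an effect already at smaller amounts and higher numbers for an effect only at larger amounts of compound), compound 2 gives the highest of the two numbers, and the single step leading to it, a 21-fold higher number from compound 1 to compound 2 (1.32 log units; beyond the scatter), is large. Compound 3 `O=C(Nc1ccc2nc(NC(=O)C3CCCCC3)sc2c1)c1ccc(Cl)cc1Cl` carries 2,4-dichlorophenyl in place of 3-cyanophenyl on a carbonyl carbon. That earlier step is the only one that bears on this change: the chlorine-bearing ring of compound 1 went with the lower number, and compound 3 brings a chlorine-bearing ring back, with a second chlorine added. On these data alone, the expectation is therefore a step down in this assay, a 13-fold lower number from compound 2 to compound 3 (1.11 log units; beyond the scatter), broadly undoing the earlier rise, though the second chlorine is untested. For compound 3 the estimate in this assay is 0.04 ug/mL, range 0.01 ug/mL to 0.16 ug/mL.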

Compound 3, half-maximal effective concentration: > 4 ug/mL
Compound 3: no number, only a limit; the forecaster's own chance of this, stated with the estimate: 5%; middle value at least 100-fold (2.00 log units) away from the limit.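

Compound 3 gives no number in this assay, only a limit of the assay: the limit of > 4 ug/mL in this assay, at which 1 of the 3 values shown sits. A chlorine-bearing ring on this carbonyl carbon therefore does not by itself go with a low number: the swap from 3-cyanophenyl to 2,4-dichlorophenyl gives an at least 7.6-fold higher number from compound 2 to compound 3 (0.88 log units; beyond the scatter), and the added chloro gives an at least 160-fold higher number from compound 1 to compound 3 (2.20 log units; beyond the scatter). In this pair, one chloro in place of hydrogen on an aromatic carbon is enough to separate the low number from the limit.

On these data alone, the true size of both steps stays open. So does whether an amine or a carboxylic acid in place of that added chloro would give a number closer to that of compound 1.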